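The source may hold more compounds than are shown below. What is called first, only, known or untested is meant among the compounds shown, and "the series" means these compounds.

Measured compounds:
compound 1 `CCCCCC(=O)c1ccc(OCCCN2CCN(C(=O)OC)CC2)cc1`, 12000 nM in an assay on isolated protein for binding affinity to histamine H2 receptor (Homo sapiens); on this read-out lower numbers stand for stronger inhibition and higher numbers for weaker inhibition; compound 2 `CCCCCC(=O)c1ccc(OCCCN2CCN(C(=O)C3CCC3)CC2)cc1`, 10200 nM; compound 3 `CCOC(=O)N1CCN(CCCOc2ccc(C(C)=O)cc2)CC1`, 39800 nM.

Compound 3 gives the highest number of the three; compound 1 lies lower, beyond the scatter, and compound 2 lower still. Among the measured compounds shown here, the only single-place step measured, a 1.2-fold lower number from compound 1 to compound 2 (0.07 log units; within the scatter), concerns the carbonyl end of the piperazine and does not touch the ketone chain, so it bears little on the present change.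

Compound 4 `CCCCCCCCC(=O)c1ccc(OCCCN2CCN(C(=O)OCC)CC2)cc1` differs from compound 3 by heptyl in place of hydrogen on a saturated chain carbon bound to a carbonyl carbon. Compound 1 and compound 3 differ in two places, the ketone chain among them, and their values point the same way as a chain extension. Compound 4 is therefore expected to move downward, a 4.0-fold lower number from compound 3 to compound 4 (0.60 log units; beyond the scatter), to an estimated 10000 nM (range 3000 nM to 30000 nM).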

Compound 4, inhibition constant: 2690 nM
Compound 4: middle estimate off by 3.7-fold (0.57 log units), on the high side; measured number below the stated range.
By their numbers in this assay, from the lowest: compound 4; then compounds 2 and 1 (each within the scatter of the next); then compound 3.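

Heptyl in place of hydrogen on a saturated chain carbon bound to a carbonyl carbon gives the first direct single-place reading at this position in this assay: a 15-fold lower number from compound 3 to compound 4 (1.17 log units; beyond the scatter). Unlike the step at the other end of the molecule, a 1.2-fold lower number from compound 1 to compound 2 (0.07 log units; within the scatter), this one lies beyond the scatter, so the ketone chain is a place where the number moves. No measurement given here bears on the cause of this step.

One step cannot define a trend with chain length. As far as these compounds go, whether a pentyl chain, a longer chain, or a chain ending in an amine or a carboxylic acid would lower the number further remains open.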